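The compounds below may be only part of what the source reports. "The series", "measured", "known", "first", "only" and "open" are said of these compounds alone.

Measured compounds:
compound 1 `CC1(C)[C@H]2CC[C@]1(C)N(Cc1cn(-c3ccccc3F)nn1)C(=O)C2` with 300 nM in a functional assay on SGC-7901 cells (Homo sapiens) for inhibition, read by MTT assay, with a stated time of 24 h; a lower number here means a stronger inhibitor, a higher number a weaker inhibitor
compound 2 `CC1(C)[C@H]2CC[C@]1(C)N(Cc1cn(-c3ccccc3O)nn1)C(=O)C2` with 410 nM in this assay

Compound 1 has the lowest of the two numbers; compound 2 is its nearest neighbour, at a 1.4-fold higher number from compound 1 to compound 2 (0.14 log units; within the scatter). Compound 3 `CC1(C)[C@H]2CC[C@]1(C)N(Cc1cn(-c3ccc(Cl)cc3)nn1)C(=O)C2` differs from compound 1 in one place: 4-chlorophenyl in place of 2-fluorophenyl on an aromatic nitrogen. Going by the values given here, the only measured step, the one from compound 1 to compound 2, also swaps the group on this same phenyl ring, and it stayed within the scatter. With no more to go on, no step beyond the scatter is expected for compound 3, so no change at the digits printed from compound 1 to compound 3 (within the scatter) is the estimate. Compound 3 is therefore expected at 300 nM, with a range from 120 nM to 800 nM.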

Compound 3, half-maximal inhibitory concentration: 410 nM
Compound 3: middle estimate off by 1.4-fold (0.14 log units), on the low side; low and high end bracket the measured number.
By their numbers in this assay, from the lowest: compounds 1, 2 and 3 (each within the scatter of the next).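

Replacing 2-fluorophenyl with 4-chlorophenyl on the aromatic nitrogen gives a 1.4-fold higher number from compound 1 to compound 3 (0.14 log units; within the scatter) in this assay and replacing 2-hydroxyphenyl with 4-chlorophenyl gives no change at the digits printed from compound 2 to compound 3 (within the scatter) as well. This position has now carried three different substituted phenyl groups, and none of the steps between them goes beyond the scatter. Nothing measured here explains this result.

Going by these compounds, whether any group on this nitrogen can move the number beyond the scatter stays open. A benzyl group, a pyridine ring or a simple alkyl chain in place of the substituted phenyl would begin to test that.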